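The compounds below may be only part of what the source reports. "The series", "measured", "known", "first", "only" and "open" are said of these compounds alone.

Measured so far:
- Compound 1, `CCc1ccc2oc(CSc3nnc(CNc4ccccc4)n3CC)nc2c1`, in an assay on isolated protein for inhibition of long-chain fatty acid transport protein 1 (Mus musculus); on this read-out lower numbers stand for stronger inhibition and higher numbers for weaker inhibition: 1800 nM
- Compound 2, `CCn1c(CNc2ccccc2)nnc1SCc1nc2cc(C(=O)C(C)C)ccc2o1`, in this assay: 520 nM
- Compound 3, `CCn1c(CNc2ccccc2)nnc1SCC(=O)Nc1ccc(C(=O)NC)cc1`, reaches only the limit of this assay at > 10000 nM.

Going by the values given here, compound 2 has the lowest of the two numbers that were obtained; its nearest neighbour is compound 1, and the single measured step, a 3.5-fold lower number from compound 1 to compound 2 (0.54 log units; beyond the scatter), is modest but beyond the scatter. Compound 3 shares the triazole side of the molecules with compound 1 and compound 2 but carries a different group on the sulfur, and for it this assay reports a limit rather than a number (the limit of > 10000 nM in this assay, at which 1 of the 3 values shown sits).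

Compound 4, `CCn1c(CNc2ccccc2)nnc1SCc1nc2cc(F)ccc2o1`, differs from compound 2 in one place: fluoro in place of isopropylcarbonyl on an aromatic carbon. Among the compounds with values here, the only step that bears on this change is the one from compound 1 to compound 2, in which isopropylcarbonyl entering in place of ethyl brought the number down by a modest amount. In compound 4 the isopropylcarbonyl leaves again and a single fluorine takes its place, so the number is expected to move back up by a step of roughly that size, a 3.8-fold higher number from compound 2 to compound 4 (0.59 log units; beyond the scatter), in this assay. Compound 4 is therefore estimated at 2000 nM, with a range from 700 nM to 6000 nM.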

Compound 4, half-maximal inhibitory concentration: 7800 nM
Beside the measured number, compound 4's estimate is 3.9-fold (0.59 log units) below it; the measured number lies above the stated range.
By their numbers in this assay, from the lowest: compound 2; then compound 1; then compound 4. At a limit, above all of these: compound 3.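

The position is no longer known from a single step: in this assay it has now been read with three groups, and fluoro gives the highest number of them, with isopropylcarbonyl the lowest and ethyl in the middle. Removing isopropylcarbonyl in favour of fluoro costs far more than the first step suggested, at a 15-fold higher number from compound 2 to compound 4 (1.18 log units; beyond the scatter), and fluoro also falls short of ethyl, at a 4.3-fold higher number from compound 1 to compound 4 (0.64 log units; beyond the scatter), so the position responds strongly to what it carries and the earlier gain was only part of its range. Across these three compounds, none of which goes against the trend, the number falls as the group on this carbon gains heavy atoms, but nothing measured here explains why the position behaves this way.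

Three groups cannot show whether the carbonyl or the carbon chain of isopropylcarbonyl accounts for its low number, and a simple ketone such as acetyl or an unbranched chain such as butyl would separate the two. Going by these compounds, how a methoxy group, an amine or a carboxylic acid would fare on this carbon also remains open.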